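From 3-chlorophenyl to 3,4-dimethoxyphenyl: an expected step

The source may hold more compounds than are shown below. What is called first, only, known or untested is meant among the compounds shown, and "the series" means these compounds.

Values in a functional assay on Gurav cells (Homo sapiens) for inhibition, read by sulforhodamine B assay; a lower number here means a stronger inhibitor of growth, a higher number a weaker inhibitor of growth:
- Compound 1 `Cc1ccc2[nH]c(-c3ccc(-c4ccc(-c5ccc(N(C)C)cc5)cc4)cc3)nc2c1`: 6240 nM
- Compound 2 `Cc1ccc2[nH]c(-c3ccc(-c4ccc(-c5cccc(Cl)c5)cc4)cc3)nc2c1`: 2120 nM

Of these two, compound 2 has the lower number at 2120 nM, which makes it the stronger inhibitor of growth. The next candidate is compound 3 `COc1ccc(-c2ccc(-c3ccc(-c4nc5cc(C)ccc5[nH]4)cc3)cc2)cc1OC`, which has not yet been measured. It carries 3,4-dimethoxyphenyl in place of 3-chlorophenyl on an aromatic carbon.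

Within the data shown here, only one measured step offers guidance, since it also exchanges one substituted phenyl group for another on an aromatic carbon. This is a 2.9-fold lower number from compound 1 to compound 2 (0.47 log units; beyond the scatter), a modest change that lies beyond the scatter. Like compound 1, compound 3 has no chlorine and carries a different group in its place. That is thin evidence, but it suggests a small move back towards the value of compound 1, 6240 nM, rather than an improvement in this assay. The expected change is a 1.7-fold higher number from compound 2 to compound 3 (0.22 log units; within the scatter), towards a higher number. For compound 3 the estimated value is 3500 nM, with an expected range of 1300 nM to 9000 nM.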

Compound 3, concentration for 50% growth inhibition: 1310 nM
Compound 3: middle estimate off by 2.7-fold (0.43 log units), on the high side; low and high end bracket the measured number.
By their numbers in this assay, from the lowest: compounds 3 and 2 (each within the scatter of the next); then compound 1.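

In this assay, putting 3,4-dimethoxyphenyl in place of 3-chlorophenyl gives a 1.6-fold lower number from compound 2 to compound 3 (0.21 log units; within the scatter), so these two compounds cannot be told apart, even though the groups differ in their atoms and the entering group carries 2 hydrogen-bond acceptors where the leaving one has none. The chlorine is therefore not needed to keep the number at this level, and a group without it does not by itself move the value back towards that of compound 1. The comparison with the dimethylamino compound is clearer, with a 4.8-fold lower number from compound 1 to compound 3 (0.68 log units; beyond the scatter), so both 3-chlorophenyl and 3,4-dimethoxyphenyl now sit apart from 4-(dimethylamino)phenyl, although nothing measured here explains why these groups give these numbers.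

The compounds shown cannot say whether either methoxy group would do as well alone, or whether the two must be present together. They also leave open what a hydroxyl, a carboxylic acid, a primary amine or a longer chain such as butoxy would do at this position, and whether any such group could bring the number clearly lower than those of compound 2 and compound 3.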